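The source may report more compounds than this note shows. Statements on the series, on what has been measured and on what is new or still open speak of the compounds shown alone.

Measured so far:
compound 1, `COc1ccc(-c2cc(-c3ccc(NS(C)(=O)=O)cc3)cnc2N)cn1`: > 4.16 h
compound 2, `COc1ccc(-c2cc(-c3ccc4nccn4c3)cnc2N)cn1`: 2.43 h

The two compounds were tested in an in vitro ADME assay on microsomes from liver (Homo sapiens) for metabolic stability; a higher number here means that the compound lasts longer, a lower number that the compound disappears faster. For compound 1 the value > 4.16 h is a limit of the assay, not a number; as the limit of > 4.16 h in this assay, at which 1 of the 2 values shown sits, notes, one of the two values sits there. Compound 2 gives 2.43 h. Compound 3, `CNC(=O)c1ccc(-c2cnc(N)c(-c3ccc(OC)nc3)c2)cc1`, is not yet measured; it differs from compound 1 by methylcarbamoyl in place of methanesulfonamido on an aromatic carbon. Within the data shown here, no step between measured compounds covers this change, so the size of the step from compound 1 to compound 3 is expected to be small, most likely within the scatter, leaning if anything toward a shorter half-life, as expressed by an at least 1.1-fold lower number from compound 1 to compound 3 (0.07 log units; that floor lies within the scatter). Compound 3 is thus estimated at 3.5 h, with a range from 1.5 h to 8 h.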

Compound 3, half-life: > 4.16 h
Compound 3: a limit, no number; the forecaster's own chance of this, stated with the estimate: 40%; middle value at least 1.1-fold (0.07 log units) away from the limit.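

Among these compounds, no step from compound 1 to compound 3 can be read in this assay, because both compounds carry a limit, not a number: the limit of > 4.16 h in this assay, at which 2 of the 3 values shown sit. The compounds shown leave open whether methylcarbamoyl in place of methanesulfonamido changes the half-life at all.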